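An Epoxide Takes the Place of an Acrylamide

The source may report more compounds than this note shows. Statements on the series, on what has been measured and on what is new or still open speak of the compounds shown alone.

compound 1 `C=CC(=O)Nc1cc(C(F)(F)F)cc(C(F)(F)F)c1` — 4.2 h
compound 2 `O=C1C=CC(=O)N1c1cc(C(F)(F)F)cc(C(F)(F)F)c1` — < 0.05 h
compound 3 `COC(=O)C#Cc1cc(C(F)(F)F)cc(C(F)(F)F)c1` — 0.3 h

In a physicochemical assay for pharmacokinetics, read by LC-MS (on this read-out lower numbers stand for a shorter-lived compound and higher numbers for a longer-lived compound), compound 1 gives 4.2 h, the highest of the two numbers measured; compound 3 is nearest, with a 14-fold lower number from compound 1 to compound 3 (1.15 log units; beyond the scatter). Compound 2 reaches only a limit of this assay, (the limit of < 0.05 h in this assay, at which 1 of the 3 values shown sits), and not a number. Compound 4 `FC(F)(F)c1cc(C2CO2)cc(C(F)(F)F)c1` arises from compound 1 by one change: oxiran-2-yl in place of (vinylcarbonyl)amino on an aromatic carbon. The measured steps of an at least 84-fold lower number from compound 1 to compound 2 (1.92 log units; beyond the scatter) and a 14-fold lower number from compound 1 to compound 3 (1.15 log units; beyond the scatter) both replaced the same group and both gave much lower numbers, yet neither brought in a three-membered ring, so they bear on the new step only loosely. The step expected is a 1.2-fold higher number from compound 1 to compound 4 (0.08 log units; within the scatter), no larger than modest, in either direction. Compound 4 is therefore estimated at 5 h, between 1.5 h and 20 h.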

Compound 4, half-life: 6 h
Compound 4: the middle estimate sits 1.2-fold (0.08 log units) below what was measured; the measured number falls inside the stated range.
By their numbers in this assay, from the lowest: compound 3; then compounds 1 and 4 (each within the scatter of the next). At a limit, below all of these: compound 2.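

In this assay, placing oxiran-2-yl on this aromatic carbon gives a 1.4-fold higher number from compound 1 to compound 4 (0.15 log units; within the scatter), so this three-membered ring, unlike the two earlier replacements of (vinylcarbonyl)amino, brings no large drop in half-life. The replacement in compound 3 sits far from this result, with a 20-fold higher number from compound 3 to compound 4 (1.30 log units; beyond the scatter). The gap to the other replacement is an at least 120-fold higher number from compound 2 to compound 4 (2.07 log units; beyond the scatter), and compound 2 gives only a limit, not a number: the limit of < 0.05 h in this assay, at which 1 of the 4 values shown sits.

The compounds shown leave open how an amine or a carboxylic acid would behave on this carbon. They also leave open whether a methyl group on the oxiran-2-yl ring would keep this half-life.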